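A few compounds are considered here, and "the series" means these few. Any claim that something is new, unique, unknown or untested is made for them only; others in the source may bear on it.

Compound 1 `Cc1cc(C)c2cccc(OCc3c(Cl)ccc(S(=O)(=O)NC4(C(=O)N5CCN(C(=O)[C@H](CCCCN(C)C)N(C)C)CC5)CCCC4)c3Cl)c2n1` — in an assay on isolated protein for binding affinity to B1 bradykinin receptor (Homo sapiens) (a lower number here means a stronger inhibitor, a higher number a weaker inhibitor), compound 1 gives < 10000 nM, which is a limit of the assay and not a number.
Compound 2 `Cc1cc(C)c2cccc(OCc3c(Cl)ccc(S(=O)(=O)NC4(C(=O)N5CCN(C(=O)C[C@@H](N)CCC[N+](C)(C)C)CC5)CCCC4)c3Cl)c2n1` — in this assay compound 2 gives < 10000 nM, likewise a limit.

Both measured compounds therefore sit at the same point, (the limit of < 10000 nM in this assay, at which 2 of the 2 values shown sit). Going by these compounds, the step that the two limits leave unreadable from compound 1 to compound 2 cannot be read from two limits, so its size and direction are unknown. Compound 2 thus stands at the limit of this assay and nowhere more exactly.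

Compound 3 `Cc1cc(C)c2cccc(OCc3c(Cl)ccc(S(=O)(=O)NC4(C(=O)N5CCN(C(=O)C[C@H](CCCN)[N+](C)(C)C)CC5)CCCC4)c3Cl)c2n1` has the same atoms as compound 2, joined differently: a group of 9 heavy atoms (7 carbon, 2 nitrogen; no ring) in place of a group of 9 heavy atoms (7 carbon, 2 nitrogen; no ring), on a saturated chain carbon bound to a carbonyl carbon. Within the data shown here, the only measured step, a step that the two limits leave unreadable from compound 1 to compound 2, touches the same part of the molecule but is unreadable, so it offers no size and no direction to carry over. Nothing shown supports expecting a gain or a loss beyond the scatter in this assay, and the limit of compound 2 is the only anchor. The estimated step is a step that the limit leaves unreadable from compound 2 to compound 3. For compound 3 the estimate in this assay is 3000 nM, with a range from 300 nM to 10000 nM, and it is quite possible that the assay again reports only a limit.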

Compound 3, inhibition constant: < 10000 nM
Compound 3: no number, only a limit (the forecaster's own chance of this, stated with the estimate: 60%); the middle value does not contradict the limit.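

In this assay compound 3 gives < 10000 nM, which is a limit of the assay and not a number. Among these compounds, no step among compound 1, compound 2 and compound 3 can therefore be read. Going by these compounds, what stays open is where each compound's true affinity lies, and whether the exchange of groups between compound 2 and compound 3 alters it at all.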